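A few compounds are considered here, and "the series" means these few. Any claim that something is new, unique, unknown or untested is made for them only; others in the source may bear on it.

Measured so far in a functional assay on cells (Mast cell, Rattus norvegicus, strain Wistar) for activation, read by fluorescence, with a stated time of 15 min (on this read-out higher numbers stand for an effect only at larger amounts of compound and lower numbers for an effect already at smaller amounts), for the series:
- compound 1 `CCCCCCCCCCCCCCCCCC(=O)N(C)C[C@@H](O)COP(=O)(O)OC[C@H](N)C(=O)O` gives 10000 nM in this series
- compound 2 `CCCCCCCCCCCCCCCCCC(=O)OC[C@@H](O)COP(=O)(O)O[C@@H](C)[C@H](N)C(=O)O` gives 2000 nM in this series

Compound 2 holds the lower of the two numbers, and its gap to compound 1 lies beyond the scatter. Compound 3 `CCCCCCCCCCCCCCCCCC(=O)OC[C@@H](O)COP(=O)(O)O[C@H]1CN[C@@H](C(=O)O)C1` departs from compound 2 by this change: a group of 8 heavy atoms (5 carbon, 1 nitrogen, 2 oxygen; one five-membered non-aromatic ring with 1 hetero atom) in place of a group of 7 heavy atoms (4 carbon, 1 nitrogen, 2 oxygen; no ring), on an oxygen with the new five-membered non-aromatic ring on the same oxygen. Among the measured compounds shown here, no measured pair covers such a change, so only a modest rise in the number is expected. The expected size is a 2.5-fold higher number from compound 2 to compound 3 (0.40 log units; beyond the scatter) in this assay as an estimate. Compound 3 is expected at 5000 nM within an estimated range of 1200 nM to 20000 nM in this series.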

Compound 3, half-maximal effective concentration: > 10000 nM
Compound 3: a limit, no number (the forecaster's own chance of this, stated with the estimate: 30%); at least 2.0-fold (0.30 log units) between middle value and limit.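

In this assay, the ring-bearing group of 8 heavy atoms in place of the open group of 7 heavy atoms, on the oxygen whose other neighbour is phosphorus, gives an at least 5.0-fold higher number from compound 2 to compound 3 (0.69 log units; beyond the scatter). Among the compounds shown here, this is the first one-place step, and it shows that the read-out responds to the group on this oxygen. Compound 3 gives a limit and not a number, so the full size of the step stays unknown: the limit of > 10000 nM in this assay, at which 1 of the 3 values shown sits.

Still open, as far as these compounds go, is whether the ring itself or some other feature of the new group accounts for the step. A six-membered non-aromatic ring or an open ethyl-bearing group on the same oxygen would help to separate these, as would the opposite stereocentres on the five-membered ring.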